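A few compounds are considered here, and "the series" means these few. Any claim that something is new, unique, unknown or untested is made for them only; others in the source may bear on it.

Going by the values given here, in an assay on isolated protein for inhibition of Dihydrofolate reductase (Mus musculus) (a lower number here means a stronger inhibitor, a higher number a weaker inhibitor), compound 1 `CN(Cc1cnc2nc(N)nc(N)c2n1)c1ccc(C(=O)NC(C/C=C/C(=O)O)C(=O)O)cc1` gives 32000 nM, the lower of the two numbers measured so far. Among the compounds with values here, compound 2 `Nc1nc(N)c2nc(CNc3ccc(C(=O)NC(C/C=C/C(=O)O)C(=O)O)cc3)cnc2n1` gives 46000 nM, and the one measured step, a 1.4-fold higher number from compound 1 to compound 2 (0.16 log units; within the scatter), changes only a group on a nitrogen on an aromatic ring. Compound 3 `CN(Cc1cnc2nc(N)nc(N)c2n1)c1ccc(C(=O)N(CCC(=O)O)CC(=O)O)cc1` differs from compound 1 elsewhere: (2-carboxyethyl)(carboxymethyl)amino in place of (1,4-dicarboxybut-3-en-1-yl)amino on a carbonyl carbon. Within the data shown here, no measured step touches this part of the molecule, so nothing indicates the direction of the change. The expected step is a 1.4-fold higher number from compound 1 to compound 3 (0.15 log units; within the scatter), with no clear direction beyond the scatter. Compound 3 is therefore estimated at 45000 nM, with a likely range from 15000 nM to 150000 nM.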

Compound 3, half-maximal inhibitory concentration: 38 nM
Estimate against measurement, compound 3: 1200-fold (3.07 log units) above, outside the stated range (below it).
By their numbers in this assay, from the lowest: compound 3; then compounds 1 and 2 (each within the scatter of the next).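

This position, the group on the carbonyl carbon, matters far more in this assay than the group on a nitrogen on an aromatic ring. Replacing (1,4-dicarboxybut-3-en-1-yl)amino with (2-carboxyethyl)(carboxymethyl)amino gives an 840-fold lower number from compound 1 to compound 3 (2.93 log units; beyond the scatter), whereas the earlier change gave only a 1.4-fold higher number from compound 1 to compound 2 (0.16 log units; within the scatter). No measurement here explains the large step.

The compounds shown leave open which part of the new group carries the gain, since the whole group changes at once. They also leave open whether a longer chain, or an amine in place of either carboxylic acid, would keep it.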